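Cytotoxicity of a thiophene series before its isopropyl member

The source may hold more compounds than are shown below. What is called first, only, known or untested is meant among the compounds shown, and "the series" means these compounds.

Compound 1 `CC1CC=C(C(=O)N(c2cc(C#CC(C)(C)C)sc2C(=O)O)C(C)C)CC1` — > 20000 nM
Compound 2 `CC(C)(C)C#Cc1cc(N(C(=O)[C@H]2CC[C@H](C)CC2)[C@H]2C[C@@H](Oc3cccnc3)C2)c(C(=O)O)s1` — > 20000 nM
Compound 3 `CC(C)(C)C#Cc1cc(N(C(=O)[C@H]2CC[C@H](C)CC2)[C@H]2CC[C@H](Oc3nccs3)CC2)c(C(=O)O)s1` — > 20000 nM

Of the compounds shown here, three have been tested in an ADME assay on MT4 cells (Homo sapiens) for cytotoxicity, with a stated time of 5 days; a higher number here means that more compound is tolerated, a lower number that less compound is tolerated. For compound 1 the result is a limit of the assay, > 20000 nM. For compound 2 the result is likewise a limit, > 20000 nM. Compound 3 also reaches only a limit in this assay, > 20000 nM, so its place among the three cannot be ranked: all three sit at the same limit (the limit of > 20000 nM in this assay, at which 3 of the 3 values shown sit). Among the compounds with values here, the one step between measured compounds that differ in a single place, a step that the two limits leave unreadable from compound 2 to compound 3, therefore cannot be sized.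

Compound 4 `CC(C)N(c1cc(C#CC(C)(C)C)sc1C(=O)O)C(=O)[C@H]1CC[C@H](C)CC1` has not yet been measured in this assay. It differs from compound 3 in one place: isopropyl in place of 4-((1,3-thiazol-2-yl)oxy)cyclohexyl on an amide-type nitrogen. Compound 1 already carries isopropyl on the amide-type nitrogen with a closely related acyl group, and it too sits at the limit. Within the data shown here, no measured step bears a readable size on this change. The step from compound 3 to compound 4 is therefore expected to be a step that the limit leaves unreadable from compound 3 to compound 4, nothing beyond the scatter. Compound 4 is estimated at 30000 nM, between 15000 nM and 100000 nM, most likely reported again as a limit.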

Compound 4, half-maximal cytotoxic concentration: > 20000 nM
Compound 4: only a limit was reported; the forecaster's own chance of this, stated with the estimate: 85%; the middle value lies beyond the limit too.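

Compound 4 also reaches only a limit in this assay, > 20000 nM. Its steps from compound 1, compound 2 and compound 3 therefore cannot be read: the limit of > 20000 nM in this assay, at which 4 of the 4 values shown sit. The compounds shown leave open how much of any of the four compounds the cells tolerate, and whether the group on the amide-type nitrogen makes any difference to that.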